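A naphthalen-1-yl group on the sulfur of compound 3

The source may hold more compounds than are shown below. What is called first, only, known or untested is meant among the compounds shown, and "the series" means these compounds.

Compound 1 `Cc1cc(C)cc(SCc2ccc(/C=C/C(=O)Nc3ccccc3N)cc2)c1` gives 11.7%
Compound 2 `Nc1ccccc1NC(=O)/C=C/c1ccc(CSc2cccc(F)c2)cc1` gives 2.25%
Compound 3 `Nc1ccccc1NC(=O)/C=C/c1ccc(CSc2ccc(C(F)(F)F)cn2)cc1` gives 6.07%

All three compounds were tested in a functional assay on HeLa cells (Homo sapiens) for inhibition, read by CCK-8 assay, with a stated time of 72 h, tested at 2 uM; on this read-out lower numbers stand for less inhibition of growth and higher numbers for more inhibition of growth at the one concentration tested. They share one core and differ only in the group carried on the sulfur. Compound 3 cannot be told apart from the other two, since the data show a number 3.8 percentage points higher from compound 2 to compound 3 (within the scatter) and a number 5.6 percentage points lower from compound 1 to compound 3 (within the scatter).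

The next compound, compound 4 `Nc1ccccc1NC(=O)/C=C/c1ccc(CSc2cccc3ccccc23)cc1`, has not been measured yet. It differs from compound 3 in one place: naphthalen-1-yl in place of 5-(trifluoromethyl)pyridin-2-yl on a sulfur. The three measured steps all change this same group, so they are the ones that bear on the new change. Besides the two already given, there is a number 9.5 percentage points lower from compound 1 to compound 2 (within the scatter). None of them goes beyond the scatter, so swapping the group on the sulfur has so far produced no clear shift in this assay. However, no measured compound carries a naphthalen-1-yl group, so this expectation rests on different groups and stays loose, with more room on the upper side. The expected change is small, with no step beyond the scatter: a number 1.9 percentage points higher from compound 3 to compound 4 (within the scatter). For compound 4 the estimated value is 8%, with an expected range from 1% to 20%.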

Compound 4, percent growth inhibition at one concentration: 20.6%
Beside the measured number, compound 4's estimate is 12.6 percentage points below it, outside the stated range (above it).
By their numbers in this assay, from the lowest: compounds 2, 3, 1 and 4 (each within the scatter of the next, the first and the last beyond it).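

In this assay the group on the sulfur can, after all, move the number beyond the scatter: naphthalen-1-yl in place of 5-(trifluoromethyl)pyridin-2-yl gives a number 14.5 percentage points higher from compound 3 to compound 4 (beyond the scatter) as a modest step, and naphthalen-1-yl in place of 3-fluorophenyl gives a number 18.4 percentage points higher from compound 2 to compound 4 (beyond the scatter) as another. This does not hold against every earlier group, since naphthalen-1-yl in place of 3,5-dimethylphenyl gives a number 8.9 percentage points higher from compound 1 to compound 4 (within the scatter) and so leaves these two compounds impossible to tell apart. The heavy-atom count does not separate compound 3 from compound 4, as both groups carry the same count, so the step goes with the exchange of one aromatic ring with a hetero atom and three fluorines for two aromatic rings of carbon only.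

The compounds shown leave open how a plain phenyl, a naphthalen-2-yl group, or a phenyl carrying an amine or a carboxylic acid would read on the same sulfur. No measured property of these groups is at hand to explain any of these steps.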